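The source may report more compounds than this note shows. Statements on the series, on what has been measured and on what is new or still open speak of the compounds shown alone.

Measured in a functional assay on MES-SA cells (Homo sapiens) for cytotoxicity, read by luminescence and CellTiter-Glo, with a stated time of 72 h; on this read-out higher numbers stand for weaker inhibition and lower numbers for stronger inhibition:
compound 1 `COC[C@H](NC(=O)c1cc(OC)no1)C(=O)N[C@@H](COC)C(=O)N[C@@H](CC(C)C)C(=O)[C@@]1(C)CO1`: 82 nM
compound 2 `COC[C@H](NC(=O)c1cc(C)on1)C(=O)N[C@@H](CC(C)C)C(=O)N[C@@H](CC(C)C)C(=O)[C@@]1(C)CO1`: 366 nM

Of the two measured compounds, compound 2 has the higher number at 366 nM, which means the weaker inhibition. Compound 1 at 82 nM lies lower, and that gap is beyond the usual scatter.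

Still unmeasured in this assay is compound 3 `COC[C@H](NC(=O)c1cc(C)on1)C(=O)N[C@@H](COC)C(=O)N[C@@H](CC(C)C)C(=O)[C@@]1(C)CO1`. Its difference from compound 2 is methoxy in place of isopropyl on a saturated chain carbon, two bonds along the chain from an amide-type nitrogen and a carbonyl carbon.

Among the measured compounds shown here, no measured pair isolates this change, so the data give no direct size for it. For the measured compounds named here, the only guide is the spread of the two values, and compound 2 at 366 nM is the upper of them. A moderate move towards a lower number is therefore expected, somewhat beyond the scatter, though a result within the scatter would not be surprising.

The expected step is a 2.4-fold lower number from compound 2 to compound 3 (0.39 log units; beyond the scatter), and this is an estimate only.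

For compound 3 the estimated value is 150 nM, with an expected range of 50 nM to 450 nM.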

Compound 3, half-maximal inhibitory concentration: 145 nM
Estimate against measurement, compound 3: 1.0-fold (0.01 log units) above; the range from low to high includes it.
By their numbers in this assay, from the lowest: compounds 1 and 3 (each within the scatter of the next); then compound 2.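

In this assay, methoxy in place of isopropyl on a saturated chain carbon, two bonds along the chain from an amide-type nitrogen and a carbonyl carbon, gives a 2.5-fold lower number from compound 2 to compound 3 (0.40 log units; beyond the scatter) and so provides the first direct size for a change at this position. The same difference, read one bond further out, is isobutyl to methoxymethyl, and in this single pair the methoxy-bearing side chain goes with the lower number and the stronger inhibition. With that side chain held constant, 5-methyl-1,2-oxazol-3-yl in place of 3-methoxy-1,2-oxazol-5-yl on a carbonyl carbon gives a 1.8-fold higher number from compound 1 to compound 3 (0.25 log units; within the scatter) and therefore does not separate these two end groups in this read-out.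

Going by these compounds, whether the step at this position keeps its size with 3-methoxy-1,2-oxazol-5-yl as the end group remains open, as does its size with any other end group. Also open, on these data alone, is how other side chains at this carbon compare, such as ethoxymethyl, hydroxymethyl or an aminomethyl group. Nothing available here bears on the reason for the step.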